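The source may report more compounds than this note shows. Statements on the series, on what has been measured and on what is new or still open speak of the compounds shown alone.

Measured so far:
Compound 1 `CC(C)(C)c1ccc(N(C(=O)c2ccco2)C(C(=O)NC2CC2)c2cccnc2)cc1` gives 52800 nM in a toxicity assay on Vero C1008 cells (Chlorocebus sabaeus) for cytotoxicity, read by neutral red uptake, with a stated time of 5 days; a higher number here means that more compound is tolerated, a lower number that less compound is tolerated.
Compound 2 `CC(C)(C)c1ccc(N(C(=O)c2ccco2)C(C(=O)NC2CCCCC2)c2cccnc2)cc1` gives 18200 nM in this assay.
Compound 3 `C[C@H](NC(=O)C(c1cccnc1)N(C(=O)c1ccco1)c1ccc(C2CCCCC2)cc1)c1ccccc1` gives 9610 nM in this assay.

Compound 3 and compound 2 give numbers within the usual scatter of each other, while compound 1 gives a higher number that lies beyond it. Compound 4 `C[C@H](NC(=O)C(c1cccnc1)N(C(=O)c1ccco1)c1ccc(-c2ccccc2)cc1)c1ccccc1` differs from compound 3 in one place: phenyl in place of cyclohexyl on an aromatic carbon. Going by the values given here, the only measured step, a 2.9-fold lower number from compound 1 to compound 2 (0.46 log units; beyond the scatter), concerns a ring on an amide-type nitrogen, not the group on the aromatic carbon changed here, so it offers little guidance. Among the compounds with values here, with no direct precedent, no step beyond the scatter is expected, a 1.0-fold higher number from compound 3 to compound 4 (0.02 log units; within the scatter). Compound 4 is therefore estimated at 10000 nM, with a likely range from 4000 nM to 25000 nM.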

Compound 4, half-maximal cytotoxic concentration: > 200000 nM
Compound 4: a limit, no number; the forecaster's own chance of this, stated with the estimate: 5%; middle value at least 20-fold (1.30 log units) from the limit.
By their numbers in this assay, from the lowest: compounds 3 and 2 (each within the scatter of the next); then compound 1. At a limit, above all of these: compound 4.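

In this assay, the group on an aromatic carbon para to a large group turns out to matter greatly, with an at least 20-fold higher number from compound 3 to compound 4 (1.31 log units; beyond the scatter). Both groups have 6 heavy atoms, so in this pair, replacing a non-aromatic ring with an aromatic one is enough for a large step. Compound 4 gives a limit, not a number: the limit of > 200000 nM in this assay, at which 1 of the 4 values shown sits.

From the compounds shown here alone, how far the true number of compound 4 lies past this limit remains open. So does what an amine or a carboxylic acid at this position would give.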